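Propargyloxy-aryl series: phenyl replacing methyl on the core

The source may hold more compounds than are shown below. What is called first, only, known or untested is meant among the compounds shown, and "the series" means these compounds.

Measured so far:
compound 1 `C#CCOc1ccc(-c2cc(-c3ccc(OCC#C)cc3)nc(-c3ccccc3)n2)cc1`: 12300 nM
compound 2 `C#CCOc1ccc(-c2cc(-c3ccccc3OCC#C)nc(C)n2)cc1`: 18100 nM

In an assay on BTI-TN-5B1-4 cells for inhibition of Amine oxidase [flavin-containing] B (Homo sapiens), read by fluorescence and Amplex Red, using microsomes, with a stated time of 30 min (a higher number here means a weaker inhibitor, a lower number a stronger inhibitor), compound 2 gives the higher of the two numbers, and compound 1 gives a number that lies within the scatter of it. Among the compounds with values here, the two structures differ in more than one place, so no single step is read from them.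

Compound 3 `C#CCOc1ccc(-c2cc(-c3ccccc3OCC#C)nc(-c3ccccc3)n2)cc1` carries phenyl in place of methyl on an aromatic carbon, phenyl in place of methyl on an aromatic carbon. The pair of compound 1 and compound 2 shows no difference beyond the scatter even across several changes, so the step from compound 2 to compound 3 is expected to be small, a 1.3-fold lower number from compound 2 to compound 3 (0.11 log units; within the scatter), with no clear direction. Compound 3 is expected at 14000 nM, range 5000 nM to 40000 nM.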

Compound 3, half-maximal inhibitory concentration: 14400 nM
Estimate against measurement, compound 3: 1.0-fold (0.01 log units) below, within the range that was stated.
By their numbers in this assay, from the lowest: compounds 1, 3 and 2 (each within the scatter of the next).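

In this assay phenyl in place of methyl, on the aromatic carbon between two ring nitrogen atoms, amounts to a 1.3-fold lower number from compound 2 to compound 3 (0.10 log units; within the scatter) and so separates nothing at this position, despite the added six-membered aromatic ring. Exchanging one group of 10 heavy atoms for another of the same composition on an aromatic carbon amounts to a 1.2-fold higher number from compound 1 to compound 3 (0.07 log units; within the scatter) and likewise separates nothing. No measurement at hand accounts for either result.

Going by these compounds, whether an amine, a carboxylic acid or a longer alkyl chain at this position would move the number beyond the scatter remains open.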